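Propyl to isobutyl: a step in adenosine receptor binding

The compounds below may be only part of what the source reports. "The series", "measured", "known", "first", "only" and "open" are said of these compounds alone.

Measured so far:
compound 1 `CC1=C(C(=O)OCC(C)C)C(c2ccco2)NC(=O)N1C`: 23%
compound 2 `CCCOC(=O)C1=C(C)N(C)C(=O)NC1c1ccoc1`: 16%

In an assay on membranes from HeLa cells for displacement of a labelled ligand from adenosine receptor A3 (Homo sapiens), read by scintillation counting, with a stated time of 180 min, tested at 1 uM (on this read-out higher numbers stand for more inhibition at the one concentration tested (going by the name of the read-out) and lower numbers for less inhibition), compound 1 gives 23% and compound 2 gives 16%. The two numbers are a few points apart, a gap inside the usual scatter of this read-out, so neither compound can be set above the other; compound 2 simply stands at the smaller of two numbers that are effectively indistinguishable. Compound 1 and compound 2 also differ in more than one place, so no single structural step can be read from them.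

Compound 3 `CC1=C(C(=O)OCC(C)C)C(c2ccoc2)NC(=O)N1C` is the next one to be tested. It differs from compound 2 by methyl in place of hydrogen on a saturated chain carbon bound to two saturated chain carbons. Within the data shown here, no measured pair shows the effect of this change, so the expectation can only rest on the narrow spread seen so far. For this assay the estimated step of a number 2 percentage points higher from compound 2 to compound 3 (within the scatter) is expected to be small, in either direction, and not beyond the scatter. Compound 3 is expected to give about 18%, in the range 4% to 34%.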

Compound 3, a percentage reported as inhibition, at one concentration (the size of the read-out at that concentration, not a potency): 16%
Estimate against measurement, compound 3: 2 percentage points above; low and high end bracket the measured number.
By their numbers in this assay, from the lowest: compounds 2, 3 and 1 (each within the scatter of the next).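

In this assay, among these compounds, the change from propoxy to isobutoxy, methyl in place of hydrogen on a saturated chain carbon bound to two saturated chain carbons, gives no change at the digits printed from compound 2 to compound 3 (within the scatter) and so provides the first single-place reading for this position: on this read-out, the added methyl cannot be told apart from the hydrogen. Compound 3 also connects compound 1 to the series through a single change, since furan-3-yl in place of furan-2-yl on a saturated ring carbon gives a number 7 percentage points lower from compound 1 to compound 3 (within the scatter) and leaves this swap equally unresolved from the scatter. No measurement at hand bears on why either step reads as it does.

As far as these compounds go, whether a longer chain such as pentyl, or a chain ending in an amine or a carboxylic acid, would move the number beyond the scatter remains open, as does the effect of a phenyl ring in place of either furan. From the compounds shown here alone, with only one concentration available for these compounds, their potencies at the receptor also remain open.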